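Flipping the Alkene Geometry in an Octynyl Uracil Series

A few compounds are considered here, and "the series" means these few. Any claim that something is new, unique, unknown or untested is made for them only; others in the source may bear on it.

Measured compounds:
compound 1, `Cc1ccc(C#Cc2cn(C/C=C\CN3C(=O)c4ccccc4C3=O)c(=O)[nH]c2=O)cc1`: 245000 nM
compound 2, `CCCCCCCCC#Cc1cn(C/C=C\CN2C(=O)c3ccccc3C2=O)c(=O)[nH]c1=O`: 45000 nM
compound 3, `O=C1c2ccccc2C(=O)N1C/C=C\Cn1cc(C#Cc2ccc(Br)cc2)c(=O)[nH]c1=O`: 448000 nM

These three compounds share one core and differ only in the group on the triple-bonded carbon. In a functional assay on L1210 cells (Mus musculus) for antiproliferative activity, read by MTT assay, with a stated time of 2 days (on this read-out higher numbers stand for weaker inhibition and lower numbers for stronger inhibition), compound 2 gives the lowest number of the three: the step of a 5.4-fold lower number from compound 1 to compound 2 (0.74 log units; beyond the scatter) and the step of a 10-fold higher number from compound 2 to compound 3 (1.00 log units; beyond the scatter) both lie beyond the scatter, so compound 2 stands apart from the others, whereas compound 1 and compound 3 are separated only by a 1.8-fold higher number from compound 1 to compound 3 (0.26 log units; within the scatter).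

Compound 4, `CCCCCCCCC#Cc1cn(C/C=C/CN2C(=O)c3ccccc3C2=O)c(=O)[nH]c1=O`, has not yet been measured. Its change from compound 2 is the two compounds have the same atoms and bonds and differ only in configuration as drawn: 1 of 1 stereo elements differ; a double bond is drawn Z in compound 2 and E in compound 4; the two compounds have the same atoms and bonds and differ only in configuration as drawn, a double bond drawn Z in compound 2 and E in compound 4.

For the measured compounds named here, none of the measured steps touches this kind of change: all of them swap the group on the triple-bonded carbon and leave the double bond as it is. There is therefore no basis in these data for predicting a shift in either direction, and the step of no change at the digits printed from compound 2 to compound 4 (within the scatter) is expected to stay within the scatter, with a wide margin of doubt. Compound 4 is estimated at 45000 nM in this assay, within a range from 12000 nM to 170000 nM.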

Compound 4, half-maximal inhibitory concentration: > 250000 nM
Compound 4: only a limit was reported; the forecaster's own chance of this, stated with the estimate: 5%; middle value at least 5.5-fold (0.74 log units) away from the limit.
By their numbers in this assay, from the lowest: compound 2; then compounds 1 and 3 (each within the scatter of the next).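

In this assay compound 4 gives > 250000 nM, which is a limit of the assay and not a number. The earlier steps shown here all swapped the group on the triple-bonded carbon, whereas here the octyl group stays in place and only the double bond changes from Z to E, and this still gives an at least 5.5-fold higher number from compound 2 to compound 4 (0.74 log units; beyond the scatter), so the geometry of the double bond matters as well as the group on the triple-bonded carbon. The shift in the read-out can be traced to that double bond alone: the fact that compounds 2 and 4 differ only in the configuration as drawn

From the compounds shown here alone, only the octyl compounds appear here in both Z and E forms, so it remains open whether the E form would also give a higher number with 4-methylphenyl or 4-bromophenyl on the triple-bonded carbon. Going by these compounds, it is also open whether a longer chain than octyl, or a chain carrying an amine or a carboxylic acid, on that same carbon would lower the number further than compound 2 does in this assay.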